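The source may report more compounds than this note shows. Statements on the series, on what has been measured and on what is new or still open speak of the compounds shown alone.

Of the compounds shown here, two of a shared core have been measured in an assay on isolated protein for binding affinity to sphingosine 1-phosphate receptor 2 (Homo sapiens), read by surface plasmon resonance (on this read-out higher numbers stand for weaker binding and lower numbers for tighter binding), so far. Compound 1, `CCCc1cc(NNC(=O)Nc2cc(Cl)nc(Cl)c2)nc2c1cnn2C`, gives 1400 nM in this assay. Compound 2, `Cc1nn(C)c2nc(NNC(=O)Nc3cc(Cl)nc(Cl)c3)cc(-c3ccco3)c12`, gives 6520 nM in this assay, the higher of the two numbers; the difference between compound 2 and compound 1 lies beyond the usual scatter, so compound 2 binds the more weakly of the pair. For the measured compounds named here, no step between compounds that differ in one place is available, since compound 1 and compound 2 differ at more than one site.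

Compound 3, `Cc1cc(NNC(=O)Nc2cc(Cl)nc(Cl)c2)nc2c1c(C)nn2C`, has not yet been measured in this assay. It is derived from compound 2 by a single change: methyl in place of furan-2-yl on an aromatic carbon Compound 3 thereby carries a small alkyl group on the core, as compound 1 does with its propyl, while keeping the remaining substitution of compound 2. On that basis the expected outcome for compound 3 is a modest step toward tighter binding, a 2.2-fold lower number from compound 2 to compound 3 (0.34 log units; beyond the scatter), though not beyond what the scatter and the gap to compound 1 would allow. Compound 3 is accordingly estimated at 3000 nM in this assay, within a range of 1000 nM to 9000 nM.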

Compound 3, dissociation constant: 11000 nM
The estimate for compound 3 lay 3.7-fold (0.56 log units) below the measured number, outside the stated range (above it).
By their numbers in this assay, from the lowest: compound 1; then compounds 2 and 3 (each within the scatter of the next).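

In this assay, methyl in place of furan-2-yl on this aromatic carbon, opposite the ring nitrogen, gives a 1.7-fold higher number from compound 2 to compound 3 (0.23 log units; within the scatter) and so does not separate the two groups. For the compounds shown here, this is the first single-place comparison, and it shows that a five-membered aromatic ring with 1 hetero atom and a methyl group, which differ by several heavy atoms, can occupy this position without a change in the number that exceeds the scatter. No measurement at hand accounts for this result.

Going by these compounds alone, whether an amine, a hydroxyl group, a phenyl ring or a longer chain such as butyl on the same carbon would give a number beyond the scatter remains open, so the tolerance seen here rests on only two groups. Compound 1 differs from compound 3 in more than one place, so the lower number of compound 1 cannot be assigned to its propyl group, and the effect of propyl at this position also remains unresolved.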